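One More Carbon in the Side Chain

The source may hold more compounds than are shown below. What is called first, only, known or untested is meant among the compounds shown, and "the series" means these compounds.

Compound 1, `N#CCCn1cnc2c(Br)c(Br)c(Br)c(Br)c21`: 2%
Compound 2, `Cc1nc2c(Br)c(Br)c(Br)c(Br)c2n1CCC#N`: 2%

In a functional assay on CCRF-CEM cells (Homo sapiens) for cytotoxicity, read by MTT assay, with a stated time of 24 h, tested at 50 uM (a lower number here means a stronger effect, a higher number a weaker effect of the compound at the concentration tested), compound 1 gives 2%, and compound 2 gives 2%. Among the compounds with values here, the one measured step, no change at the digits printed from compound 1 to compound 2 (within the scatter), concerns methyl in place of hydrogen on an aromatic carbon, not the chain. Compound 3, `N#CCCCn1cnc2c(Br)c(Br)c(Br)c(Br)c21`, differs from compound 1 by cyanomethyl in place of cyano on a saturated chain carbon, two bonds along the chain from an aromatic nitrogen. Within the data shown here, no measured step bears on this change, so the expectation rests on compound 1 already sitting at the strong end with 2%. Compound 3 is therefore expected at 5%, from 1% to 25%, an estimated step of a number 3 percentage points higher from compound 1 to compound 3 (within the scatter).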

Compound 3, a percentage reported as activity, at one concentration (the size of the read-out at that concentration, not a potency): 2%
The estimate for compound 3 lay 3 percentage points above the measured number, within the range that was stated.
By their numbers in this assay, from the lowest: compounds 1, 2 and 3 (each within the scatter of the next).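

Putting cyanomethyl in place of cyano on a saturated chain carbon, two bonds along the chain from an aromatic nitrogen, gives in this assay no change at the digits printed from compound 1 to compound 3 (within the scatter) for this change. The side chain can therefore carry one more carbon, with its nitrile kept at the end, without any visible loss of effect at the concentration tested. No measurement shown gives a reason for this result.

Since all of these compounds sit near the strong end of the scale, the read-out may have little room to reveal a difference. On these data alone, whether a longer chain, or an amine or a carboxylic acid in place of the nitrile, would hold this level remains open.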